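This account rests on a few compounds, and the source may have more. Where it says the series, first, only, none or still open, it means among the compounds named here.

Measured compounds, in an assay on CHO cells for displacement of a labelled ligand from adenosine receptor A1 (Homo sapiens), read by scintillation counting, with a stated time of 3 h; on this read-out lower numbers stand for stronger inhibition and higher numbers for weaker inhibition:
compound 1 `Cn1c(-c2ccc(O)cc2)nc2c(NC3CCCC3)ncnc21`: 17 nM
compound 2 `CCn1c(-c2ccccc2)nc2c(NC3CCCCC3)ncnc21`: 10 nM
compound 3 `COc1ccc(-c2nc3c(NC4CCCC4)ncnc3n2C)cc1`: 75 nM

Compound 3 stands highest of the three numbers in this assay; its nearest neighbour is compound 1 and its furthest is compound 2, both separated from it by more than the scatter. Compound 4 `Cn1c(-c2ccc(F)cc2)nc2c(NC3CCCC3)ncnc21` is not yet measured. Its change from compound 3 is fluoro in place of methoxy on an aromatic carbon.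

Within the data shown here, only one measured step touches this position: a 4.4-fold higher number from compound 1 to compound 3 (0.64 log units; beyond the scatter). That step altered the same oxygen that now leaves altogether, and it was modest but clear, so the substituent on this aromatic carbon does move the number. Among the measured compounds shown here, compound 2 carries no substituent on that ring at all, but it also differs from compound 3 elsewhere, so its value shows only that a bare ring is compatible with a low number. For the measured compounds named here, the step to compound 4 is expected to run toward lower numbers, since the methoxy that sits on the high-numbered compound 3 is removed, though fluoro is not hydroxy and no step tells how close to compound 1 it lands. Compound 4 is therefore estimated at 28 nM, with a likely range of 9 nM to 80 nM, which means an expected step of a 2.7-fold lower number from compound 3 to compound 4 (0.43 log units; beyond the scatter).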

Compound 4, inhibition constant: 6.2 nM
Compound 4: the middle estimate sits 4.5-fold (0.65 log units) above what was measured; the whole stated range lies above it.
By their numbers in this assay, from the lowest: compounds 4, 2 and 1 (each within the scatter of the next, the first and the last beyond it); then compound 3.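

In this assay, among these compounds, the change from 4-methoxyphenyl to 4-fluorophenyl gives a 12-fold lower number from compound 3 to compound 4 (1.08 log units; beyond the scatter) and so counts as a large step, where the only earlier step at this aromatic carbon was modest. The hydroxy of compound 1 also turns out not to mark the low end at this position: a 2.7-fold lower number from compound 1 to compound 4 (0.44 log units; beyond the scatter) is beyond the scatter, which puts the three groups in the order fluoro, hydroxy, methoxy from the lowest number to the highest, and both oxygen-bearing groups give higher numbers than fluoro on this core. Nothing available explains why the number moves in this order.

The three compounds that differ only here do not tell where chloro, methyl, trifluoromethyl, nitrile or an amine would fall in this order, or whether any of them would reach a lower number than fluoro. Going by these compounds, the bare ring also stays unplaced on this core, since compound 2 differs from compound 4 in more than this one place, and whether the fluoro, hydroxy, methoxy order holds on the core of compound 2 remains open.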